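The source may hold more compounds than are shown below. What is called first, only, known or untested is meant among the compounds shown, and "the series" means these compounds.

Of the compounds shown here, three built on one shared core have been measured in a functional assay on A-375 cells (Homo sapiens) for antiproliferative activity, read by CCK-8 assay, with a stated time of 72 h, tested at 8 uM; on this read-out higher numbers stand for a stronger effect at the one concentration tested and lower numbers for a weaker effect. Compound 1 `Nc1ccccc1NC(=O)c1ccc(CSC(=S)N2CCN(C(c3ccccc3)c3ccccc3)CC2)cc1` gives 8.4%, and compound 2 `COc1ccc(N2CCN(C(=S)SCc3ccc(C(=O)Nc4ccccc4N)cc3)CC2)cc1` gives 35.9%. Compound 3 `Nc1ccccc1NC(=O)c1ccc(CSC(=S)N2CCN(c3ccc(F)cc3)CC2)cc1` gives 76.3%, the highest of the three numbers, and its gaps to both other compounds lie beyond the usual scatter. Among the measured compounds there is one single-point change, a number 40.4 percentage points higher from compound 2 to compound 3 (beyond the scatter), and it is a large step.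

Compound 4 `CN1CCN(C(=S)SCc2ccc(C(=O)Nc3ccccc3N)cc2)CC1` has not yet been measured. It differs from compound 3 in one place: methyl in place of 4-fluorophenyl on an amine nitrogen in a ring. Going by the values given here, no measured step replaces a six-membered aromatic ring on this amine nitrogen in a ring with a methyl, so the step from compound 2 to compound 3 bears on it only in showing that what sits on this ring nitrogen can shift the read-out by a large amount. Compound 1, which carries a larger group on the same ring nitrogen, gives a far lower number than compound 3. With the aromatic ring of carbon only removed altogether in compound 4, a drop is expected. For compound 4 the step is estimated as a number 46.3 percentage points lower from compound 3 to compound 4 (beyond the scatter), towards weaker inhibition. For compound 4 the estimate is 30%, within a range from 5% to 60%.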

Compound 4, a percentage reported as inhibition, at one concentration (the size of the read-out at that concentration, not a potency): 91.6%
The estimate for compound 4 lay 61.6 percentage points below the measured number; measured number outside the range, above it.
By their numbers in this assay, from the lowest: compound 1; then compound 2; then compound 3; then compound 4.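

Putting a methyl on this amine nitrogen in a ring gives a number 15.3 percentage points higher from compound 3 to compound 4 (beyond the scatter) in this assay, and the same change on the methoxy-bearing compound gives a number 55.7 percentage points higher from compound 2 to compound 4 (beyond the scatter) as its step. The earlier compounds shown here all carried an aromatic ring on this nitrogen, so they showed only that the read-out moves with the group there; these steps show that no such ring is needed for a high number, and that a group with a single heavy atom and no ring can give the highest number of the four. Nothing available here explains why the methyl does better than either aromatic group.

The compounds shown jump from a methyl straight to groups built on aromatic rings, so it remains open how the number behaves in between, for instance with an ethyl, a longer chain such as butyl, or a cyclohexyl ring on this nitrogen. A hydrogen on the nitrogen, or a hydroxyethyl chain there, would also show whether the methyl itself matters, although a read-out at one concentration would still not give a potency.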